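The compounds below may be only part of what the source reports. "The series", "measured", "known", "first", "only" and "open" are said of these compounds alone.

Measured compounds in an assay on isolated protein for inhibition of E3 ubiquitin-protein ligase Mdm2 (Homo sapiens), read by fluorescence polarization, with a stated time of 30 min; on this read-out higher numbers stand for weaker inhibition and lower numbers for stronger inhibition:
compound 1, `CCOc1cc(C(C)(C)C)ccc1C1=NC(c2ccc(Cl)cc2)C(c2ccc(Cl)cc2)N1C(=O)NCCCCCCCC(=O)NO`, gives 340 nM
compound 2, `CCOc1cc(C(C)(C)C)ccc1C1=NC(c2ccc(Cl)cc2)C(c2ccc(Cl)cc2)N1C(=O)NCCCCCCC(=O)Nc1ccccc1N`, gives 620 nM
compound 3, `CCOc1cc(C(C)(C)C)ccc1C1=NC(c2ccc(Cl)cc2)C(c2ccc(Cl)cc2)N1C(=O)NCCCCCC(=O)Nc1ccccc1N`, gives 1430 nM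

Compound 3 stands highest of the three numbers. Its nearest neighbour is compound 2, as shown by a 2.3-fold higher number from compound 2 to compound 3 (0.36 log units; beyond the scatter), and the furthest is compound 1, as shown by a 4.2-fold higher number from compound 1 to compound 3 (0.62 log units; beyond the scatter). Compound 4, `CCOc1cc(C(C)(C)C)ccc1C1=NC(c2ccc(Cl)cc2)C(c2ccc(Cl)cc2)N1C(=O)NCCCCC(=O)Nc1ccccc1N`, continues the same series: the change is (2-aminophenyl)carbamoyl in place of ((2-aminophenyl)carbamoyl)methyl on a saturated chain carbon, four bonds along the chain from an amide-type nitrogen. The step that bears most directly on it is the one of the same kind, one bond further out, a 2.3-fold higher number from compound 2 to compound 3 (0.36 log units; beyond the scatter), which shortened the chain by one unit and raised the number modestly. The step of a 1.8-fold higher number from compound 1 to compound 2 (0.26 log units; within the scatter) changed the end group rather than the chain length and stayed within the scatter, so it carries less weight here. Compound 4 is therefore expected to show a further modest rise, a 2.1-fold higher number from compound 3 to compound 4 (0.32 log units; beyond the scatter). Compound 4 is estimated at 3000 nM, with a range from 1400 nM to 7000 nM.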

Compound 4, inhibition constant: 960 nM
For compound 4 the middle estimate is 3.1-fold (0.49 log units) above the measured one; measured number below the stated range.
By their numbers in this assay, from the lowest: compounds 1, 2, 4 and 3 (each within the scatter of the next, the first and the last beyond it).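

In this assay, the further shortening of the chain at this place, four bonds along the chain from an amide-type nitrogen, does not repeat the rise seen one bond further out: a 1.5-fold lower number from compound 3 to compound 4 (0.17 log units; within the scatter) stays inside the scatter. The two-unit change, a 1.5-fold higher number from compound 2 to compound 4 (0.19 log units; within the scatter), is also within the scatter, so the (2-aminophenyl)carbamoyl chains shown form no steady trend with length, and compound 4 is the one that goes against such a trend. Only the comparison with the hydroxycarbamoyl end group separates clearly, with a 2.8-fold higher number from compound 1 to compound 4 (0.45 log units; beyond the scatter) beyond the scatter. Going by these compounds, how a carboxylic acid at the chain end, or a longer chain, would read in this assay remains open. Nothing given here explains why the number stops rising at this chain length.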